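This account rests on a few compounds, and the source may have more. Where it says the series, first, only, none or still open, it means among the compounds named here.

Measured compounds:
Compound 1 `N#C/N=C1\N(CCCCCCOc2ccc(Cl)cc2)C(=O)CN1c1ccncc1`: 3440 nM
Compound 2 `N#C/N=C1\N(CCCCCCCOc2ccc(Cl)cc2)C(=O)CN1c1ccncc1`: 3340 nM
Compound 3 `N#C/N=C1\N(CCCCCOc2ccc(Cl)cc2)C(=O)C(c2ccccc2)N1c1ccncc1`: 337 nM

In a functional assay on DLD-1 cells (Homo sapiens) for cytotoxicity (a higher number here means a weaker inhibitor, a lower number a stronger inhibitor), compound 3 gives the lowest number of the three, and its steps to compound 1 and compound 2 both lie beyond the scatter. Compound 1 and compound 2 differ by (4-chlorophenoxy)methyl in place of 4-chlorophenoxy on a saturated chain carbon, six bonds along the chain from an amide-type nitrogen in a ring; this step, a 1.0-fold lower number from compound 1 to compound 2 (0.01 log units; within the scatter), lies within the scatter. How the core of compound 3 differs from the core of compound 1 is not broken down here. Compound 4 `N#C/N=C1\N(CCCCCCOc2ccc(Cl)cc2)C(=O)C(c2ccccc2)N1c1ccncc1` is not yet measured in this assay; it differs from compound 3 by (4-chlorophenoxy)methyl in place of 4-chlorophenoxy on a saturated chain carbon, five bonds along the chain from an amide-type nitrogen in a ring. This is the same kind of change as from compound 1 to compound 2, but the place differs: five bonds along the chain from the amide-type nitrogen instead of six. Because a 1.0-fold lower number from compound 1 to compound 2 (0.01 log units; within the scatter) was within the scatter, compound 4 is expected to stand close to compound 3, an estimated step of a 1.0-fold higher number from compound 3 to compound 4 (0.00 log units; within the scatter). The estimate for compound 4 is 340 nM, expected between 150 nM and 800 nM.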

Compound 4, half-maximal inhibitory concentration: 37 nM
For compound 4 the middle estimate is 9.2-fold (0.96 log units) above the measured one, and the stated range ends above it.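

In this assay, placing (4-chlorophenoxy)methyl for 4-chlorophenoxy gives a 9.1-fold lower number from compound 3 to compound 4 (0.96 log units; beyond the scatter), while phenyl in place of hydrogen on a saturated ring carbon gives a 93-fold lower number from compound 1 to compound 4 (1.97 log units; beyond the scatter). The chain change therefore did not carry over from one core to the other with the same size: the same change on two cores in this assay, a 1.0-fold lower number (0.01 log units; within the scatter) from compound 1 to compound 2 and a 9.1-fold lower number (0.96 log units; beyond the scatter) from compound 3 to compound 4, 8.8-fold (0.95 log units) apart, beyond the scatter of two such steps This rests on a single pair per core, and the change sits five bonds along the chain in one pair and six in the other, so the data do not separate the effect of the core from that of the place.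

The compounds shown leave open how a longer chain would fare on the core of compound 3. They also leave open whether an amine or a carboxylic acid could stand in for the 4-chlorophenoxy group.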